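Hydroxy for methyl on the amide side chain, applied twice

A few compounds are considered here, and "the series" means these few. Any claim that something is new, unique, unknown or untested is made for them only; others in the source may bear on it.

Three compounds share a core and differ only in the amide attached to the pyridine ring. Compound 1 `CCC(=O)Nc1cc(Oc2ccc(Nc3nccc4[nH]cc(-c5ccc(F)cc5)c(=O)c34)cc2F)ccn1` carries a propanoyl group; in a functional assay on MKN-45 cells (Homo sapiens) for antiproliferative activity, read by MTT assay, with a stated time of 72 h, tested at 10 uM (a lower number here means less inhibition, a higher number more inhibition at the concentration tested (going by the name of the read-out)), compound 1 gives 92.1%. Compound 2 `O=C(CO)Nc1cc(Oc2ccc(Nc3nccc4[nH]cc(-c5ccc(F)cc5)c(=O)c34)cc2F)ccn1` differs from it by hydroxy in place of methyl on a saturated chain carbon bound to a carbonyl carbon, and in this assay compound 2 gives 63%, so that the step is a number 29.1 percentage points lower from compound 1 to compound 2 (beyond the scatter). Compound 3 `CC(C)(C)C(=O)Nc1cc(Oc2ccc(Nc3nccc4[nH]cc(-c5ccc(F)cc5)c(=O)c34)cc2F)ccn1` differs from compound 1 by tert-butyl in place of ethyl on a carbonyl carbon, and compound 3 gives 62.5%, a step of a number 29.6 percentage points lower from compound 1 to compound 3 (beyond the scatter). Compound 2 and compound 3 sit close together, the step of a number 0.5 percentage points lower from compound 2 to compound 3 (within the scatter) lying within the scatter.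

Compound 4 `CC(C)(O)C(=O)Nc1cc(Oc2ccc(Nc3nccc4[nH]cc(-c5ccc(F)cc5)c(=O)c34)cc2F)ccn1` is not yet measured. It differs from compound 3 by hydroxy in place of methyl on a saturated chain carbon bound to a carbonyl carbon and two saturated chain carbons. This is the same kind of change as from compound 1 to compound 2, but the place is not identical: in compound 2 the hydroxy sits on a saturated chain carbon bound to a carbonyl carbon, whereas in compound 4 it sits on a saturated chain carbon bound to a carbonyl carbon and two saturated chain carbons.

Compound 3 already stands where compound 2 does. If the same kind of change lowers the read-out again, the expected step from compound 3 to compound 4 is a number 17.5 percentage points lower from compound 3 to compound 4 (beyond the scatter), somewhat smaller than a number 29.1 percentage points lower from compound 1 to compound 2 (beyond the scatter) because compound 3 already gives 62.5% as the starting point. For compound 4 in this assay the estimate is 45%, expected between 25% and 65%.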

Compound 4, a percentage reported as inhibition, at one concentration (the size of the read-out at that concentration, not a potency): 57.8%
Beside the measured number, compound 4's estimate is 12.8 percentage points below it, within the range that was stated.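

Carried from the propanoyl amide to the tert-butyl amide, hydroxy in place of methyl does not repeat its result in this assay: the same change on two cores in this assay, a number 29.1 percentage points lower (beyond the scatter) from compound 1 to compound 2 and a number 4.7 percentage points lower (within the scatter) from compound 3 to compound 4, 24.4 percentage points apart, beyond the scatter of two such steps. The new step, a number 4.7 percentage points lower from compound 3 to compound 4 (within the scatter), stays inside the scatter, as does a number 5.2 percentage points lower from compound 2 to compound 4 (within the scatter), so compound 2, compound 3 and compound 4 cannot be told apart here, while compound 1 stands clear of compound 4, with a number 34.3 percentage points lower from compound 1 to compound 4 (beyond the scatter). For the compounds shown here, this shows that the size of the step for this change on one amide does not carry over to another, but with only two such pairs, each read at a single concentration, it gives no rule for other amides and no reason for the difference.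

On these data alone, it remains open whether a longer chain such as butyl on the carbonyl carbon would keep the high reading of compound 1 or would instead join the level shared by the other three compounds. As far as these compounds go, it is equally open how an amine such as dimethylamino, placed on the side chain instead of hydroxy, would read on either amide.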